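Swapping amino for methoxy on the aryl ketone of compound 1

The source may hold more compounds than are shown below. What is called first, only, known or untested is meant among the compounds shown, and "the series" means these compounds.

Compound 1 `COc1cc(-c2cc(/C=C/C(=O)c3ccc(N)cc3)[nH]n2)cc(OC)c1OC` and compound 2 `COc1ccc(-c2cc(/C=C/C(=O)c3ccc(N)cc3)[nH]n2)cc1OC` share a core and were measured in a functional assay on UO-31 cells (Homo sapiens) for cytotoxicity, read by sulforhodamine B assay, with a stated time of 48 h, tested at 0.1 uM; a higher number here means a weaker effect of the compound at the concentration tested, a lower number a stronger effect. In this assay compound 1 gives 91%, the lower of the two numbers, and compound 2 gives 99%; the step of a number 8 percentage points higher from compound 1 to compound 2 (within the scatter) lies within the scatter. Compound 3 `COc1ccc(C(=O)/C=C/c2cc(-c3cc(OC)c(OC)c(OC)c3)n[nH]2)cc1` differs from compound 1 by methoxy in place of amino on an aromatic carbon. Within the data shown here, no measured pair shows this exchange; the only step in hand concerns a different ring and was itself within the scatter, so it offers no pointer to the direction or size of a change here. With nothing in the data to suggest otherwise, the step of a number 2 percentage points higher from compound 1 to compound 3 (within the scatter) is expected to stay within the scatter. Compound 3 is therefore estimated to give 93%, with a range from 78% to 104%.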

Compound 3, a percentage reported as activity, at one concentration (the size of the read-out at that concentration, not a potency): 96%
For compound 3 the middle estimate is 3 percentage points below the measured one; low and high end bracket the measured number.
By their numbers in this assay, from the lowest: compounds 1, 3 and 2 (each within the scatter of the next).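

Among these compounds, the exchange of 4-aminophenyl for 4-methoxyphenyl gives the first reading at this position, on the aryl ketone side of the shared core, where the earlier pair had varied only the other ring. In this assay, the step of a number 5 percentage points higher from compound 1 to compound 3 (within the scatter) shows that, at the single concentration tested, this position accepts a swap from amino to methoxy, with its hydrogen-bond donor count going from one to none, without a shift beyond the usual scatter. No available evidence bears on why this is so.

From the compounds shown here alone, what remains open is whether a carboxylic acid, a nitrile or a longer alkoxy chain at this position would move the read-out beyond the scatter. Going by these compounds, it is also open whether the same exchange would behave alike on compound 2.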